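The compounds below may be only part of what the source reports. "The series", "measured", "known", "first", "only" and "open" are said of these compounds alone.

Measured so far:
Compound 1 `Cc1c(C(=O)N=C(N)N)cc(S(C)(=O)=O)c(Cl)c1C`, in a functional assay for inhibition of sodium/hydrogen exchanger (Oryctolagus cuniculus); a lower number here means a stronger inhibitor, a higher number a weaker inhibitor: 58 nM.
Compound 2 `Cc1cc(C#N)c(S(C)(=O)=O)cc1C(=O)N=C(N)N`, in this assay: 70 nM.

Compound 2 stands within the scatter of compound 1; the two numbers cannot be told apart on what has been measured. Compound 3 `Cc1c(C(=O)N=C(N)N)cc(S(C)(=O)=O)c(C#N)c1C` differs from compound 2 by methyl in place of hydrogen on an aromatic carbon. For the measured compounds named here, no measured pair isolates this change. Compound 1 already carries two methyl groups and sits within the scatter of compound 2, so nothing here points to a step beyond the scatter in either direction. Compound 3 is expected at about 60 nM in this assay, within 25 nM to 150 nM. The step this estimate means, a 1.2-fold lower number from compound 2 to compound 3 (0.07 log units; within the scatter), is expected to stay within the scatter.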

Compound 3, half-maximal inhibitory concentration: 370 nM
Beside the measured number, compound 3's estimate is 6.2-fold (0.79 log units) below it; the measured number lies above the stated range.
By their numbers in this assay, from the lowest: compounds 1 and 2 (each within the scatter of the next); then compound 3.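

In this assay, methyl in place of hydrogen on the aromatic carbon ortho to a cyano group gives a 5.3-fold higher number from compound 2 to compound 3 (0.72 log units; beyond the scatter), so this position is not neutral when cyano is present. With both methyl groups in place, cyano in place of chloro gives a 6.4-fold higher number from compound 1 to compound 3 (0.80 log units; beyond the scatter); among these three compounds, the higher number appears only where methyl and cyano occur together. Nothing shown accounts for either step. From the compounds shown here alone, it remains open whether ethyl in place of that methyl would raise the number further. Going by these compounds, it also remains open whether an amine in place of cyano, with both methyl groups kept, would give a number nearer compound 1 or compound 3.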